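Predicting a Chloro-Fluoro Aniline Analogue from Two Measured Compounds

The compounds below may be only part of what the source reports. "The series", "measured", "known", "first", "only" and "open" are said of these compounds alone.

Compound 1 `C=CC(=O)Nc1cccc(NC(=O)CSc2nc(Nc3cccc(Cl)c3)c3ccccc3n2)c1`: 7830 nM
Compound 2 `C=CC(=O)Nc1cccc(NC(=O)CSc2nc(Nc3cccc(OC)c3)c3ccccc3n2)c1`: 24200 nM

In a functional assay on MGC-803 cells (Homo sapiens) for inhibition, read by MTT assay, with a stated time of 72 h (on this read-out lower numbers stand for stronger inhibition and higher numbers for weaker inhibition), compound 2 stands highest of the two numbers measured, its nearest neighbour being compound 1. Within the data shown here, the only step known, a 3.1-fold higher number from compound 1 to compound 2 (0.49 log units; beyond the scatter), came with methoxy in place of chloro. Compound 3 `C=CC(=O)Nc1cccc(NC(=O)CSc2nc(Nc3ccc(F)c(Cl)c3)c3ccccc3n2)c1` reverses that exchange and adds fluorine: 3-chloro-4-fluorophenyl in place of 3-methoxyphenyl on a nitrogen on an aromatic ring. Since chloro is restored, the number is expected to fall by about the size of that step, giving a 3.2-fold lower number from compound 2 to compound 3 (0.51 log units; beyond the scatter). The estimate for compound 3 is therefore 7500 nM, within 2500 nM to 22000 nM, with the added fluorine untested.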

Compound 3, half-maximal inhibitory concentration: 7850 nM
Beside the measured number, compound 3's estimate is 1.0-fold (0.02 log units) below it, and the stated range covers the measured number.
By their numbers in this assay, from the lowest: compounds 1 and 3 (each within the scatter of the next); then compound 2.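

In this assay fluoro in place of hydrogen on an aromatic carbon gives a 1.0-fold higher number from compound 1 to compound 3 (0.00 log units; within the scatter), so this added fluorine separates compound 3 from compound 1 by no more than the scatter. The full exchange of 3-methoxyphenyl for 3-chloro-4-fluorophenyl gives a 3.1-fold lower number from compound 2 to compound 3 (0.49 log units; beyond the scatter), which leaves methoxy compound 2 apart from both chloro compounds. No evidence here explains either step. The compounds shown leave open whether fluoro would matter at another ring carbon or without the chloro. They also leave open how bromo, trifluoromethyl or an amine on this ring would compare.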